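Thiophen-2-yl in place of 4-chlorophenyl: compound 4

The source may hold more compounds than are shown below. What is called first, only, known or untested is meant among the compounds shown, and "the series" means these compounds.

Measured so far in a functional assay on FM3A cells (Mus musculus) for antiproliferative activity; on this read-out higher numbers stand for weaker inhibition and lower numbers for stronger inhibition:
compound 1 `COc1cc(C(=O)c2sc(-c3ccc(Cl)cc3)cc2N)cc(OC)c1OC` gives 90 nM;
compound 2 `COc1cccc(-c2cc(N)c(C(=O)c3cc(OC)c(OC)c(OC)c3)s2)c1` gives 36 nM;
compound 3 `COc1cc(C(=O)c2sc(-c3ccc(C)cc3)cc2N)cc(OC)c1OC` gives 16 nM.

Compound 1 stands highest of the three numbers. Its nearest neighbour is compound 2, reached by a 2.5-fold lower number from compound 1 to compound 2 (0.40 log units; beyond the scatter), and its furthest is compound 3, reached by a 5.6-fold lower number from compound 1 to compound 3 (0.75 log units; beyond the scatter); between them lies a 2.3-fold lower number from compound 2 to compound 3 (0.35 log units; beyond the scatter).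

Compound 4 `COc1cc(C(=O)c2sc(-c3cccs3)cc2N)cc(OC)c1OC` is not yet measured. It differs from compound 1 in one place: thiophen-2-yl in place of 4-chlorophenyl on an aromatic carbon.

Two measured steps start from compound 1 and change the same position: a 2.5-fold lower number from compound 1 to compound 2 (0.40 log units; beyond the scatter) and a 5.6-fold lower number from compound 1 to compound 3 (0.75 log units; beyond the scatter). Within the data shown here, both lower the number, though neither exchanges the six-membered ring for a five-membered one, so the case of compound 4 has no direct precedent. Among the measured compounds shown here, with every change at this position so far having lowered the number, a modest step downward is expected, a 1.8-fold lower number from compound 1 to compound 4 (0.26 log units; within the scatter), with a wide range because the ring itself changes. Compound 4 is therefore estimated at 50 nM, expected between 15 nM and 180 nM in this assay.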

Compound 4, half-maximal inhibitory concentration: 1.7 nM
Compound 4: the middle estimate sits 29-fold (1.47 log units) above what was measured; measured number below the stated range.
By their numbers in this assay, from the lowest: compound 4; then compound 3; then compound 2; then compound 1.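

In this assay, thiophen-2-yl on this aromatic carbon next to the ring sulfur gives a much larger drop than either phenyl exchange did (a 53-fold lower number from compound 1 to compound 4 (1.72 log units; beyond the scatter)). The drop remains beyond the scatter against the two phenyl-bearing compounds with lower numbers than compound 1 (a 21-fold lower number from compound 2 to compound 4 (1.33 log units; beyond the scatter); a 9.4-fold lower number from compound 3 to compound 4 (0.97 log units; beyond the scatter)), so the earlier spread among substituted phenyl groups did not reveal how far the number could fall once the ring itself changed, and compound 4 has the lowest number of the four. Nothing available here accounts for this gain.

Open, going by these compounds, is whether the gain is particular to thiophen-2-yl or extends to thiophen-3-yl, furan-2-yl or a pyridine ring. Also open, on these data alone, is whether a methyl or methoxy group on the thiophene ring would keep it.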